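The source may report more compounds than this note shows. Statements on the series, on what has been measured and on what is new or still open speak of the compounds shown alone.

Measured so far:
- compound 1, `CCCCCCCC/C=C\CCCCCCC(=O)c1ccccc1`: in an assay on isolated protein for inhibition of Fatty-acid amide hydrolase 1 (Homo sapiens) (on this read-out higher numbers stand for weaker inhibition and lower numbers for stronger inhibition), compound 1 gives > 100000 nM, which is a limit of the assay and not a number.
- compound 2, `CCCCCCCC/C=C\CCCCCCC(=O)c1nc2cccnc2o1`: in this assay compound 2 gives 11 nM.

Among the measured compounds shown here, compound 2 therefore stands as the only number among the values shown; the other value is a limit, (the limit of > 100000 nM in this assay, at which 1 of the 2 values shown sits).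

Compound 3, `CCCCCCCC/C=C\CCCCCCC(=O)c1nc2ncccc2o1`, is not yet measured. It differs from compound 2 in one place: a group of 9 heavy atoms (6 carbon, 2 nitrogen, 1 oxygen; one five-membered aromatic ring with 2 hetero atoms, one six-membered aromatic ring with 1 hetero atom) in place of a group of 9 heavy atoms (6 carbon, 2 nitrogen, 1 oxygen; one five-membered aromatic ring with 2 hetero atoms, one six-membered aromatic ring with 1 hetero atom), on a carbonyl carbon; the two have the same atoms, joined differently. For the measured compounds named here, the only measured step, an at least 9000-fold lower number from compound 1 to compound 2 (3.95 log units; beyond the scatter), concerns putting this whole group in place of the group in compound 1, so it speaks to the worth of the group itself, not to how its atoms are arranged. Compound 3 keeps the group and only rearranges it, so a much smaller step is expected, a 1.4-fold higher number from compound 2 to compound 3 (0.13 log units; within the scatter), probably none beyond the scatter. For compound 3 the estimated value is 15 nM, with a range from 3 nM to 80 nM.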

Compound 3, inhibition constant: 2.3 nM
For compound 3 the middle estimate is 6.5-fold (0.81 log units) above the measured one, outside the stated range (below it).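

Rearranging the atoms of the group on the carbonyl carbon, with nothing added or removed, gives a 4.8-fold lower number from compound 2 to compound 3 (0.68 log units; beyond the scatter) in this assay. So at this position the arrangement of the atoms matters for inhibition, not only the presence of the group, and compound 3 gives the lower number of the pair. Compound 1 gives > 100000 nM, a limit of the assay and not a number, so an at least 43000-fold lower number from compound 1 to compound 3 (4.63 log units; beyond the scatter) gives only the smallest possible size of that step, not its exact size.

The compounds shown leave open whether a third placement of the ring nitrogen, a second ring nitrogen or a chloro substituent on the ring would lower the number further. They also leave open how a shorter chain or a carboxylic acid at the chain's far end would change it, and why the rearrangement has this effect.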